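Pyridin-4-yl in place of 4-aminophenyl: an expectation

The compounds below may be only part of what the source reports. "The series", "measured", "known", "first", "only" and "open" are said of these compounds alone.

The measured compounds:
compound 1, `COc1ccc(S(=O)(=O)N2CCc3cccc(-c4ccc(N)cc4)c32)cc1`, 262 nM in a functional assay on KB-VIN10 cells (Homo sapiens) for inhibition, with a stated time of 72 h; on this read-out higher numbers stand for weaker inhibition and lower numbers for stronger inhibition
compound 2, `COc1ccc(S(=O)(=O)N2CCc3cccc(-c4ccc(F)nc4)c32)cc1`, 151 nM in this assay
compound 3, `COc1ccc(S(=O)(=O)N2CCc3cccc(-c4ccc(N(C)C)cc4)c32)cc1`, 553 nM in this assay

Among these three numbers compound 1 sits between the other two. Its step to compound 2 is a 1.7-fold lower number from compound 1 to compound 2 (0.24 log units; within the scatter), which does not clear the scatter, whereas the step to compound 3 is a 2.1-fold higher number from compound 1 to compound 3 (0.32 log units; beyond the scatter), a modest loss that does. Compound 4 is `COc1ccc(S(=O)(=O)N2CCc3cccc(-c4ccncc4)c32)cc1`, and it differs from compound 1 in one place: pyridin-4-yl in place of 4-aminophenyl on an aromatic carbon.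

For the measured compounds named here, two measured steps bear on this change. The move from compound 1 to compound 2 also exchanged the 4-aminophenyl for a nitrogen-containing six-membered ring and gave a 1.7-fold lower number from compound 1 to compound 2 (0.24 log units; within the scatter). The move from compound 1 to compound 3 altered the amino group and gave a 2.1-fold higher number from compound 1 to compound 3 (0.32 log units; beyond the scatter). Neither step is large, and the change to compound 4 resembles the former more than the latter, so no step beyond the scatter is expected in this assay, with a slight lean toward a lower number. The expected step is therefore a 1.2-fold lower number from compound 1 to compound 4 (0.10 log units; within the scatter), and compound 4 is estimated at 210 nM, in the range 90 nM to 480 nM.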

Compound 4, half-maximal inhibitory concentration: 106 nM
Estimate against measurement, compound 4: 2.0-fold (0.30 log units) above; measured number inside the range.
By their numbers in this assay, from the lowest: compounds 4, 2 and 1 (each within the scatter of the next, the first and the last beyond it); then compound 3.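

In this assay, pyridin-4-yl can take the place of 4-aminophenyl on this aromatic carbon with a change that clears the scatter (a 2.5-fold lower number from compound 1 to compound 4 (0.39 log units; beyond the scatter)), so the amino group is not needed at this position for inhibition in this range. The gap from the dimethylamino analogue is wider (a 5.2-fold lower number from compound 3 to compound 4 (0.72 log units; beyond the scatter)), while pyridin-4-yl and 6-fluoropyridin-3-yl cannot be told apart here (a 1.4-fold lower number from compound 2 to compound 4 (0.15 log units; within the scatter)), so these two nitrogen-containing rings serve alike at this position. Nothing measured beyond these numbers accounts for the steps.

The compounds shown leave open what the ring nitrogen of pyridin-4-yl contributes, a question that an unsubstituted phenyl would address. They also leave open whether unsubstituted pyridin-3-yl, a pyrimidine or a five-membered ring such as thiazole would fit this position equally well.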